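The source may hold more compounds than are shown below. What is called first, only, known or untested is meant among the compounds shown, and "the series" means these compounds.

Three members of this series have numbers in a functional assay on A549 cells (Homo sapiens) for inhibition, read by sulforhodamine B assay, with a stated time of 48 h; a lower number here means a stronger inhibitor of growth, a higher number a weaker inhibitor of growth. Compound 1 `N=C(N)c1ccc(-c2ccc(-c3ccc(F)cc3)s2)cc1` gives 2120 nM. Compound 2 `N=C(N)c1ccc(-c2ccc(-c3ccc(Cl)cc3)s2)cc1F` gives 217 nM, and compound 3 `COc1cc(OC)cc(-c2ccc(-c3ccc(C(=N)N)c(F)c3)s2)c1` gives 400 nM; the numbers for compound 2 and compound 3 lie within the scatter of each other, while compound 1 sits beyond the scatter with a higher number. Compound 4 `COc1ccc(-c2ccc(-c3ccc(C(=N)N)c(F)c3)s2)cc1` has not been measured in this assay. Relative to compound 2 the change is methoxy in place of chloro on an aromatic carbon. Going by the values given here, no step between measured compounds is known for this change. Since compound 3, which carries two methoxy groups, gives 400 nM, a small step is expected, toward a higher number if anything, within or near the scatter. Compound 4 is expected to give 400 nM, within 150 nM to 1100 nM. The expected step is a 1.8-fold higher number from compound 2 to compound 4 (0.27 log units; within the scatter).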

Compound 4, concentration for 50% growth inhibition: 4760 nM
Compound 4: middle estimate off by 12-fold (1.08 log units), on the low side, outside the stated range (above it).
By their numbers in this assay, from the lowest: compounds 2 and 3 (each within the scatter of the next); then compound 1; then compound 4.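

In this assay methoxy in place of chloro on an aromatic carbon, para to a large group, gives a 22-fold higher number from compound 2 to compound 4 (1.34 log units; beyond the scatter) and so shows this position is far from indifferent to the swap. Going by these compounds alone, the value of compound 3 400 nM with its two methoxy groups does not carry over to the single methoxy group of compound 4. Nothing available here explains the loss. Going by these compounds, whether methyl or an amine in this place stays close to compound 2 remains open. Compound 1 and compound 2 differ in two places, so the separate contributions of chloro and the ring fluorine cannot be read.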